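Adding Methylamino to Compound 3

The compounds below may be only part of what the source reports. "The series", "measured", "known", "first", "only" and "open" are said of these compounds alone.

In a functional assay (aorta) for inhibition, with Rattus norvegicus as the target, with a stated time of 8 days (a higher number here means a weaker inhibitor, a lower number a stronger inhibitor), compound 1 `Cc1nsc(-c2ccc(N3CCN(c4cccc(C(F)(F)F)c4)CC3)cc2)n1` gives 10 nM as its reading. Compound 2 `Cc1nsc(-c2ccnc(N3CCN(c4cccc(C(F)(F)F)c4)CC3)n2)n1` has > 100 nM as its result, which is a limit and not a number. Compound 3 `FC(F)(F)c1cccc(N2CCN(c3ccc(-c4ncns4)nn3)CC2)c1` gives 70 nM and so holds the higher of the two true numbers, a gap to compound 1 beyond the scatter. Compound 4 `CNc1nsc(-c2ccc(N3CCN(c4cccc(C(F)(F)F)c4)CC3)nn2)n1` differs from compound 3 by methylamino in place of hydrogen on an aromatic carbon, a change counted as methylamino in place of hydrogen on an aromatic carbon and not yet measured. Among the measured compounds shown here, no measured pair isolates this change, so any expectation in this assay is loose. Compound 1 at 10 nM shows that lower numbers occur among these compounds. A modest move toward a stronger inhibitor is expected, estimated as a 2.3-fold lower number from compound 3 to compound 4 (0.37 log units; beyond the scatter) and only just beyond the scatter. Compound 4 is estimated at 30 nM with 8 nM to 110 nM as the likely span.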

Compound 4, half-maximal inhibitory concentration: 3 nM
For compound 4 the middle estimate is 10-fold (1.00 log units) above the measured one; the measured number lies below the stated range.
By their numbers in this assay, from the lowest: compound 4; then compound 1; then compound 3. At a limit, above all of these: compound 2.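

In this assay, putting methylamino in place of hydrogen on the aromatic carbon between two ring nitrogen atoms gives a 23-fold lower number from compound 3 to compound 4 (1.37 log units; beyond the scatter), a large step. Among the compounds shown here, this is the first measured pair to isolate a change at this position, and it shows that replacing the hydrogen there can strengthen inhibition markedly. No measurement shown accounts for the size of this step. A single pair cannot show whether this result is specific to methylamino. From the compounds shown here alone, how a plain amino group, dimethylamino or a longer chain on the nitrogen would behave at this position remains open.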